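The source may hold more compounds than are shown below. What is called first, only, known or untested is meant among the compounds shown, and "the series" means these compounds.

Measured so far in a functional assay on L1210 cells (Mus musculus) for antiproliferative activity; on this read-out lower numbers stand for lower potency and higher numbers for higher potency (the scale is a negative logarithm):
Compound 1, `CCOC(=O)c1ccc(/N=N/N(C)CC(C)C)cc1`, gives 2.8.
Compound 2, `CCN(C)/N=N/c1ccc(NC(N)=O)cc1`, gives 3.87.
Compound 3, `CN(C)/N=N/c1ccc(NC(N)=O)cc1`, gives 3.97.

Compound 2 stands second highest of the three numbers in this assay. Its nearest neighbour is compound 3, and the step of a number 0.10 log units higher from compound 2 to compound 3 (within the scatter) is too small to tell the two apart. The furthest is compound 1, which lies beyond the scatter below compound 2.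

Compound 4, `CCOC(=O)c1ccc(/N=N/N(C)CC)cc1`, has not yet been measured in this assay. Against compound 2 the change is ethoxycarbonyl in place of ureido on an aromatic carbon. Among the compounds with values here, no measured pair differs only in this way, so no step bears on it directly. Within the data shown here, the one measured step, a number 0.10 log units higher from compound 2 to compound 3 (within the scatter), concerns only the chain on the amine nitrogen, so it offers no guide to swapping the aromatic substituent. The best hint is compound 1, which also carries the ethoxycarbonyl group but a different chain on the amine nitrogen; compound 1 gives 2.8, the lowest of the three. Compound 4 is therefore expected to fall close to compound 1, which would mean a downward step a number 0.97 log units lower from compound 2 to compound 4 (beyond the scatter) beyond the scatter. The estimate for compound 4 is 2.9, with a range from 2.3 to 3.5.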

Compound 4, logarithm of the reciprocal of the active concentration, log(1/C): 3.01
The estimate for compound 4 lay 0.11 log units below the measured number; the measured number falls inside the stated range.
By their numbers in this assay, from the lowest: compounds 1 and 4 (each within the scatter of the next); then compounds 2 and 3 (each within the scatter of the next).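

In this assay the change on the aromatic carbon now has a size of its own: with the same chain on the amine nitrogen, ethoxycarbonyl in place of ureido gives a clear drop (a number 0.86 log units lower from compound 2 to compound 4 (beyond the scatter)). The chain can now be tested with ethoxycarbonyl on the ring as well as with ureido: methyl in place of isopropyl gives a step that cannot be told from the scatter (a number 0.21 log units higher from compound 1 to compound 4 (within the scatter)), as does the chain change made with ureido (a number 0.10 log units higher from compound 2 to compound 3 (within the scatter)). So among these four compounds the aromatic substituent moves the number beyond the scatter and neither chain change does, though no measurement here explains that difference.

Within the data shown here, only two groups have been compared on this aromatic carbon, so it remains open whether a carboxylic acid, an amine or an acetamide there would give numbers closer to those of the ureido compounds or the ethoxycarbonyl compounds. As far as these compounds go, it is also open whether a longer chain on the amine nitrogen, such as butyl, would stay within the scatter when paired with ureido.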